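The source may report more compounds than this note shows. Statements on the series, on what has been measured and on what is new or still open speak of the compounds shown alone.

Measured compounds:
Compound 1 `Nc1sc(-c2ccc(Cl)cc2)c(-c2ccc(Cl)cc2)c1C(=O)N1CCOCC1` gives 1870 nM in a functional assay on A549 cells (Homo sapiens) for inhibition, read by sulforhodamine B assay, with a stated time of 72 h; a lower number here means a stronger inhibitor, a higher number a weaker inhibitor.
Compound 2 `CCN(CC)CCNC(=O)Nc1sc(-c2ccc(Cl)cc2)c(-c2ccc(Cl)cc2)c1C(=O)NC1CC1` has the entry "not determined" (no result reported) in this assay, so no number was returned for it.
Compound 3 `CS(=O)(=O)Nc1sc(-c2ccc(Cl)cc2)c(-c2ccc(Cl)cc2)c1C(=O)NC1CC1` has the entry "not determined" (no result reported) in this assay, so no number was returned for it.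

Going by the values given here, compound 1 stands alone on the numbers: it carries the only value the series has in this assay, and the entries for compound 2 and compound 3 give nothing that can be ranked against it. Among the compounds with values here, there is no pair of measured compounds differing in one place, so no measured step exists to set the scale of what a change at the carbonyl carbon does in this assay.

Compound 4 `COC(=O)c1c(N)sc(-c2ccc(Cl)cc2)c1-c1ccc(Cl)cc1` differs from compound 1 at one position:

methoxy in place of morpholin-4-yl on a carbonyl carbon

The morpholin-4-yl group leaves the carbonyl carbon and a methoxy enters in its place; read one bond further out, a (morpholin-4-yl)carbonyl becomes a methoxycarbonyl. Within the data shown here, with no measured step to lean on, the expectation in this assay is a modest step, more likely toward a weaker inhibitor than a stronger one, and it may well not exceed the usual scatter of repeated measurements.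

Compound 4 is accordingly estimated at 2600 nM, with a range from 700 nM to 9000 nM. The step of a 1.4-fold higher number from compound 1 to compound 4 (0.14 log units; within the scatter) is expected to be small and directed toward weaker inhibition, with the value of compound 1 at 1870 nM as the only anchor.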

Compound 4, half-maximal inhibitory concentration: 5040 nM
Beside the measured number, compound 4's estimate is 1.9-fold (0.29 log units) below it; the measured number falls inside the stated range.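

In this assay the carbonyl carbon now has its first measured step: a 2.7-fold higher number from compound 1 to compound 4 (0.43 log units; beyond the scatter), a modest change but one beyond the scatter. The group on this carbonyl carbon therefore registers in the read-out, and replacing morpholin-4-yl with methoxy weakens inhibition without abolishing it, with compound 4 still giving a number at 5040 nM. No supporting evidence accompanies this step, so the shift cannot be assigned to any particular feature of either group.

A single step cannot show whether the trend would hold for other groups at this carbonyl carbon, such as ethoxy, piperidin-1-yl or a free carboxylic acid, or whether the ring of morpholin-4-yl matters more than its oxygen. The entries for compound 2 and compound 3 carry no number, so the cyclopropylamino group on the carbonyl carbon and the changes they bear on the amino group of the shared core cannot be read against compound 1 or compound 4.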